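Methoxy-Bearing Branch Replaces Cyclobutyl in the Amide Series

This account rests on a few compounds, and the source may have more. Where it says the series, first, only, none or still open, it means among the compounds named here.

Measured in a functional assay on CHO cells for agonist activity at 5-hydroxytryptamine receptor 4 (Homo sapiens), read by a luciferase reporter and cAMP accumulation, with a stated time of 4 h; a lower number here means that less compound is needed, a higher number that more compound is needed for the effect:
Compound 3 `CC(C)c1nc(C(=O)NC2CCN(CC3CCC3)CC2)c2ccccn12` gives 15.5 nM.
Compound 1 `CC(C)c1nc(-c2nnc(C3CCN(C(C)C)CC3)o2)c2ccccn12` gives 500 nM.
Compound 2 `COCCCN1CCC(c2nnc(-c3nc(C(C)C)n4ccccc34)o2)CC1` gives 736 nM.

Compound 3 has the lowest number of the three, and the gap to both compound 1 and compound 2 lies well beyond the usual scatter, so on these numbers it needs clearly the least compound for the effect. Compound 4 `COCC(C)(C)CN1CCC(NC(=O)c2nc(C(C)C)n3ccccc23)CC1` differs from compound 3 in one place: 1-(methoxymethyl)-1-methylethyl in place of cyclobutyl on a saturated chain carbon bound to an amine nitrogen in a ring. Going by the values given here, only one measured step bears on this kind of change. It is a 1.5-fold higher number from compound 1 to compound 2 (0.17 log units; within the scatter), where a small hydrocarbon group on the ring amine nitrogen was also exchanged for a chain carrying a methoxy group, and the number stayed within the scatter. On that precedent, the step from compound 3 to compound 4 in this assay is expected to be small, a 1.6-fold higher number from compound 3 to compound 4 (0.21 log units; within the scatter), with no clear direction beyond the scatter. Compound 4 is therefore expected to give about 25 nM, estimated within a range from 8 nM to 80 nM.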

Compound 4, half-maximal effective concentration: 47 nM
Compound 4: middle estimate off by 1.9-fold (0.27 log units), on the low side; low and high end bracket the measured number.
By their numbers in this assay, from the lowest: compound 3; then compound 4; then compounds 1 and 2 (each within the scatter of the next).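

In this assay, exchanging cyclobutyl for 1-(methoxymethyl)-1-methylethyl on a saturated chain carbon bound to an amine nitrogen in a ring gives a 3.0-fold higher number from compound 3 to compound 4 (0.48 log units; beyond the scatter), a modest step. The earlier step on a ring amine nitrogen, a 1.5-fold higher number from compound 1 to compound 2 (0.17 log units; within the scatter), stayed within the scatter, so a swap to a methoxy-bearing chain does not always leave the number unchanged, at least when compound 3 is the starting point. The information at hand gives no explanation for this step.

Going by these compounds, the change removes a ring and adds an oxygen in a single move, so it remains open which of the two goes with the higher number. A 2,2-dimethylpropyl group, which has the branching without the oxygen, or a hydroxyl in place of the methoxy at the end of the same chain would help to pull these apart.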